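Swapping Chlorine for Bromine on a Shared Core

The compounds below may be only part of what the source reports. "The series", "measured", "known", "first", "only" and "open" are said of these compounds alone.

Of the compounds shown here, two built on the same core have been measured so far. Compound 1, `CNC(=O)c1cc(Oc2ccc(NC(=O)c3cc4cccnc4n(-c4ccc(Br)cc4)c3=O)cc2)ccn1`, gives 1180 nM in a functional assay on HT-29 cells (Homo sapiens) for antiproliferative activity, read by MTT assay, with a stated time of 72 h; a lower number here means a stronger inhibitor, a higher number a weaker inhibitor. Compound 2, `CCCNC(=O)c1cc(Oc2ccc(NC(=O)c3cc4cccnc4n(-c4ccc(Cl)cc4)c3=O)cc2)ccn1`, gives 390 nM in this assay. On these two numbers compound 2 stands lowest, and its gap to compound 1 lies beyond the usual scatter of repeated measurements. The two compounds differ in more than one place at once, so the numbers alone do not tell which of the differences matters.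

Compound 3, `CCCNC(=O)c1cc(Oc2ccc(NC(=O)c3cc4cccnc4n(-c4ccc(Br)cc4)c3=O)cc2)ccn1`, keeps the amide chain of compound 2 and changes only one thing: bromo in place of chloro on an aromatic carbon. Among the compounds with values here, no step between measured compounds isolates this single change, so the expectation rests on the general observation that such a swap of one halogen for a closely related one rarely moves numbers much. In this assay the step of a 1.2-fold higher number from compound 2 to compound 3 (0.06 log units; within the scatter) is expected to stay within the scatter, with no clear direction. Compound 3 is therefore expected to give about 450 nM in this assay, with a likely range from 200 nM to 1000 nM.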

Compound 3, half-maximal inhibitory concentration: 530 nM
Compound 3: the middle estimate sits 1.2-fold (0.07 log units) below what was measured; low and high end bracket the measured number.
By their numbers in this assay, from the lowest: compounds 2 and 3 (each within the scatter of the next); then compound 1.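

With the 4-chlorophenyl replaced by 4-bromophenyl and nothing else altered, this assay shows a 1.4-fold higher number from compound 2 to compound 3 (0.13 log units; within the scatter), so at this position, para to a large group, the two halogens cannot be told apart by this measure. Within the data shown here, compound 3 also provides the first reading of the amide chain alone: ethyl in place of hydrogen on the saturated chain carbon bound to the amide-type nitrogen gives a 2.2-fold lower number from compound 1 to compound 3 (0.35 log units; beyond the scatter), and of the two single changes now readable, only this one goes beyond the scatter. Nothing available here explains either step.

As far as these compounds go, the halogen step has been read on only one amide chain and the chain step only with bromo in place, so whether each would hold with the other group present remains open. Also open, from the compounds shown here alone, is how this assay would respond to a fluoro or methoxy group in place of the halogen, or to a longer chain or a terminal amine on the amide nitrogen.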